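This account rests on a few compounds, and the source may have more. Where it says the series, first, only, none or still open, it means among the compounds named here.

Compound 1 `O=C1C(Nc2ccccc2F)=CC(=O)c2c1nc1n2[C@H]2OC[C@@H](O)[C@H]2OC1`, compound 2 `O=C1C(N2CCC2)=CC(=O)c2c1nc1n2[C@H]2OC[C@@H](O)[C@H]2OC1` and compound 3 `CCOc1ccccc1NC1=CC(=O)c2c(nc3n2[C@H]2OC[C@@H](O)[C@H]2OC3)C1=O` share one core. In a functional assay on MCF7 cells (Homo sapiens) for inhibition, read by sulforhodamine B assay (on this read-out higher numbers stand for weaker inhibition and lower numbers for stronger inhibition), compound 1 gives > 4000 nM, which is a limit of the assay and not a number. Compound 2 gives > 16000 nM, also a limit. Compound 3 gives > 4000 nM, again a limit, and so stands at the limit of > 4000 nM in this assay, at which 2 of the 3 values shown sit. The next compound is compound 4 `O=C1C(Nc2cccc(Cl)c2)=CC(=O)c2c1nc1n2[C@H]2OC[C@@H](O)[C@H]2OC1`, which differs from compound 3 by 3-chlorophenyl in place of 2-ethoxyphenyl on an amine nitrogen. Two measured changes bear on this one: a step that the two limits leave unreadable from compound 1 to compound 3, which alters the group on that same nitrogen, and a step that the two limits leave unreadable from compound 1 to compound 2, which replaces the whole amine. Neither has a size that can be carried over, so neither supports a step beyond the scatter in this assay or favours a direction. The expected change is a step that the limit leaves unreadable from compound 3 to compound 4, and another limit is quite likely. For compound 4 the estimate is 5000 nM, with an expected range from 1500 nM to 16000 nM.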

Compound 4, half-maximal inhibitory concentration: 2970 nM
For compound 4 the middle estimate is 1.7-fold (0.23 log units) above the measured one; measured number inside the range.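

In this assay compound 4 is the first compound shown to give a number rather than a limit, and the exchange of the whole amine reads as an at least 5.3-fold lower number from compound 2 to compound 4 (0.73 log units; beyond the scatter). Changing only the aryl group on the amine nitrogen reads as an at least 1.3-fold lower number from compound 3 to compound 4 (0.12 log units; that floor lies within the scatter) and as an at least 1.3-fold lower number from compound 1 to compound 4 (0.12 log units; that floor lies within the scatter), and neither floor settles whether 3-chlorophenyl truly differs from 2-ethoxyphenyl or 2-fluorophenyl. The true size of these two steps stays hidden behind the limit shared by compound 1 and compound 3: the limit of > 4000 nM in this assay, at which 2 of the 4 values shown sit.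

Going by these compounds, the steps among compound 1, compound 2 and compound 3 cannot be read, so the ranking of those three stays open. Also open, on these data alone, is whether an unsubstituted phenyl, a bromophenyl or a longer alkyl chain on the same nitrogen would give a number at all.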